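The compounds below may be only part of what the source reports. "The series", "measured", "known", "first", "only" and "open" are said of these compounds alone.

Measured so far in an assay on HEK293 cells for binding affinity to D(4) dopamine receptor (Homo sapiens), read by radioligand binding; on this read-out lower numbers stand for stronger inhibition and higher numbers for weaker inhibition:
compound 1 `CC(C)(C)C(=O)NCCCCN1CCN(c2ccc(Cl)cc2)CC1`: 12.6 nM
compound 2 `COc1ccc(N2CCN(CCCCNC(=O)C(C)(C)C)CC2)cc1`: 316 nM

Compound 1 gives the lowest of the two numbers in this assay. Among the compounds with values here, its only neighbour is compound 2, reached by a 25-fold higher number from compound 1 to compound 2 (1.40 log units; beyond the scatter), a step beyond the scatter.

The next compound, compound 3 `CC(C)(C)C(=O)NCCCCCN1CCN(c2ccc(Cl)cc2)CC1`, is not yet measured. It differs from compound 1 by (((tert-butyl)carbonyl)amino)methyl in place of ((tert-butyl)carbonyl)amino on a saturated chain carbon, four bonds along the chain from an amine nitrogen in a ring, so the saturated chain between the amine nitrogen in the ring and the amide is lengthened by one carbon while the shared core of compound 1 and the tert-butyl amide are kept.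

Within the data shown here, no measured step bears on this change: the one step in hand concerns the aromatic substituent, not the chain. With nothing to point either way, the expected step is a 1.2-fold higher number from compound 1 to compound 3 (0.08 log units; within the scatter), i.e. none beyond the scatter. Compound 3 is therefore estimated at 15 nM in this assay, with a range of 5 nM to 50 nM.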

Compound 3, inhibition constant: 126 nM
Compound 3: the middle estimate sits 8.4-fold (0.92 log units) below what was measured; the measured number lies above the stated range.
By their numbers in this assay, from the lowest: compound 1; then compound 3; then compound 2.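

In this assay the saturated chain between the amine nitrogen in the ring and the amide is not a neutral spacer: adding one carbon gives a 10-fold higher number from compound 1 to compound 3 (1.00 log units; beyond the scatter) while the shared core and the tert-butyl amide stay unchanged. The series therefore responds beyond the scatter at a second place, alongside the aromatic substituent, where the change from chloro to methoxy gave a 25-fold higher number from compound 1 to compound 2 (1.40 log units; beyond the scatter). No available evidence accounts for the effect of the added carbon.

A single pair cannot show whether the trend continues with a longer chain or reverses with a shorter one, or whether the methoxy and chloro substituents would differ in the same way on the lengthened chain. As far as these compounds go, whether the chain step depends on the tert-butyl amide also remains open, and a cyclohexyl amide or a phenyl amide in its place would test this.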